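Fluoro to acetyl on the phenyl of compound 2

This account rests on a few compounds, and the source may have more. Where it says the series, first, only, none or still open, it means among the compounds named here.

compound 1 `c1ccc(-c2cn3ccnc3c(-c3ccc4ncn(C5CCCCC5)c4c3)n2)cc1`: 21.7%
compound 2 `Fc1ccc(-c2cn3ccnc3c(-c3ccc4ncn(C5CCCCC5)c4c3)n2)cc1`: 10.7%

In a functional assay on SF-268 cells (Homo sapiens) for inhibition, read by sulforhodamine B assay, with a stated time of 48 h, tested at 10 uM (on this read-out lower numbers stand for less inhibition and higher numbers for more inhibition at the one concentration tested (going by the name of the read-out)), compound 1 gives 21.7% and compound 2 gives 10.7%. Among the compounds with values here, compound 2 thus stands lowest of the two numbers, with compound 1 as its only neighbour. Within the data shown here, the single measured step, a number 11 percentage points lower from compound 1 to compound 2 (beyond the scatter), is the only guide, and it concerns fluoro against hydrogen, not acetyl. Compound 3 `CC(=O)c1ccc(-c2cn3ccnc3c(-c3ccc4ncn(C5CCCCC5)c4c3)n2)cc1` differs from compound 2 by acetyl in place of fluoro on an aromatic carbon. Among the measured compounds shown here, no measured step covers acetyl, so little can be carried over. Compound 3 is expected to return roughly to the level of compound 1, a step of a number 9.3 percentage points higher from compound 2 to compound 3 (within the scatter) on this assay, with wide uncertainty. The estimate for compound 3 is 20%, between 5% and 40%.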

Compound 3, a percentage reported as inhibition, at one concentration (the size of the read-out at that concentration, not a potency): 5.01%
Compound 3: the middle estimate sits 15 percentage points above what was measured; measured number inside the range.
By their numbers in this assay, from the lowest: compounds 3 and 2 (each within the scatter of the next); then compound 1.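

In this assay the change from 4-fluorophenyl to 4-acetylphenyl gives a number 5.7 percentage points lower from compound 2 to compound 3 (within the scatter) and so does not separate the two groups at this position. Acetyl in place of hydrogen gives a number 16.7 percentage points lower from compound 1 to compound 3 (beyond the scatter) as a step, so acetyl, like fluoro, stands beyond the scatter from hydrogen here. Nothing measured bears on the reason for this result. Still open, as far as these compounds go, is whether an amine or a carboxylic acid at this position would stay with compound 2 and compound 3 or return to the level of compound 1.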